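Working notes on three measured analogues and one to come

A few compounds are considered here, and "the series" means these few. Any claim that something is new, unique, unknown or untested is made for them only; others in the source may bear on it.

Three compounds have so far been run in a functional assay on UACC-62 cells (Homo sapiens); on this read-out higher numbers stand for weaker inhibition of growth and lower numbers for stronger inhibition of growth. Compound 1 `O=S(=O)(/C=C/c1ccc(F)cc1Cl)Cc1ccc(Nc2ncnc3ccccc23)cc1` gives 100000 nM in this assay. Compound 2 `O=S(=O)(/C=C/c1ccc(C(F)(F)F)cc1F)Cc1ccc(Nc2ncnc3ccccc23)cc1` gives 100000 nM in this assay. Compound 3 `O=S(=O)(/C=C/c1ccc(C(F)(F)F)cc1F)Cc1ccc(Nc2ncnc3cc(Cl)ccc23)cc1` reaches only a limit of the assay in this assay, > 100000 nM, and thus sits at the limit of > 100000 nM in this assay, at which 1 of the 3 values shown sits; no number is known for it.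

Compound 2 and compound 1 share a core and differ by 2-chloro-4-fluorophenyl in place of 2-fluoro-4-(trifluoromethyl)phenyl on a double-bonded chain carbon bound to a double-bonded chain carbon; the step reads no change at the digits printed from compound 2 to compound 1 (within the scatter). Compound 2 and compound 3 differ in the core by chloro in place of hydrogen on an aromatic carbon; the step of a number no lower from compound 2 to compound 3 (the limit leaves the size open) gives only a bound, so its size is not known.

Compound 4 `O=S(=O)(/C=C/c1ccc(F)cc1Cl)Cc1ccc(Nc2ncnc3cc(Cl)ccc23)cc1` has not been measured. It differs from compound 3 by 2-chloro-4-fluorophenyl in place of 2-fluoro-4-(trifluoromethyl)phenyl on a double-bonded chain carbon bound to a double-bonded chain carbon, the same change at the same place as between compound 2 and compound 1. In this assay the step from compound 3 to compound 4 is expected to be a number no higher from compound 3 to compound 4 (the limit leaves the size open), resting on no change at the digits printed from compound 2 to compound 1 (within the scatter). For compound 4 the estimate in this assay is 100000 nM, within a range of 40000 nM to 250000 nM, and a limit rather than a number is expected to be the likely report.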

Compound 4, concentration for 50% growth inhibition: 72000 nM
Beside the measured number, compound 4's estimate is 1.4-fold (0.14 log units) above it; the measured number falls inside the stated range.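

In this assay the 2-chloro-4-fluorophenyl in place of 2-fluoro-4-(trifluoromethyl)phenyl gives an at least 1.3-fold lower number from compound 3 to compound 4 (0.14 log units; that floor lies within the scatter), and set beside the same change on the other core the result stays unresolved: the same change on two cores in this assay, no change at the digits printed (within the scatter) from compound 2 to compound 1 and an at least 1.3-fold lower number (0.14 log units; that floor lies within the scatter) from compound 3 to compound 4; the limit leaves it open whether they differ. The chloro in place of hydrogen on an aromatic carbon gives a 1.4-fold lower number from compound 1 to compound 4 (0.14 log units; within the scatter), and its comparison with the earlier step is equally unsettled: the same change on two cores in this assay, a number no lower (the limit leaves the size open) from compound 2 to compound 3 and a 1.4-fold lower number (0.14 log units; within the scatter) from compound 1 to compound 4; the limit leaves it open whether they differ. Compound 3 gives only a limit of the assay, > 100000 nM, so these pairs show no conflict in carrying either change from one core to the other but do not show that either change keeps its size.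

No step read here is shown to lie beyond the scatter, so the series has yet to give a clear effect of either change on growth inhibition. As far as these compounds go, whether an amine on the shared core, or a nitrile or carboxylic acid on the phenyl ring, would give a different read-out remains open.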